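A few compounds are considered here, and "the series" means these few. Any claim that something is new, unique, unknown or untested is made for them only; others in the source may bear on it.

Compound 1 `c1ccc(-c2cc(NCC3CC3)ncn2)nc1`: 10000 nM
Compound 2 `COCCNc1nc(NCC2CC2)cc(-c2ccccn2)n1`: 10000 nM

In a functional assay on HEK293 cells for agonist activity at G-protein coupled receptor 39 (Mus musculus), read by inositol phosphate accumulation (a lower number here means that less compound is needed, a higher number that more compound is needed for the effect), compound 1 gives 10000 nM and compound 2 gives 10000 nM; compound 2 is level with compound 1 at the digits shown, and the step of no change at the digits printed from compound 1 to compound 2 (within the scatter) lies within the scatter. Compound 3 `CC(C)(C)CNc1nc(NCC2CC2)cc(-c2ccccn2)n1` differs from compound 2 by tert-butyl in place of methoxymethyl on a saturated chain carbon bound to a nitrogen on an aromatic ring. Within the data shown here, no measured step touches this chain; the only step, from hydrogen to the amino substituent, moved nothing. Compound 3 is therefore expected to stay near compound 2, with a step of no change at the digits printed from compound 2 to compound 3 (within the scatter), estimated at 10000 nM in the range 3000 nM to 30000 nM.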

Compound 3, half-maximal effective concentration: 1500 nM
Compound 3: the middle estimate sits 6.7-fold (0.82 log units) above what was measured; the measured number lies below the stated range.
By their numbers in this assay, from the lowest: compound 3; then compounds 1 and 2 (each within the scatter of the next).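

In this assay, this position does respond to substitution: neopentylamino in place of hydrogen on an aromatic carbon gives a 6.7-fold lower number from compound 1 to compound 3 (0.82 log units; beyond the scatter), whereas (2-methoxyethyl)amino gave no change at the digits printed from compound 1 to compound 2 (within the scatter). The change from methoxymethyl to tert-butyl on the saturated chain carbon gives a 6.7-fold lower number from compound 2 to compound 3 (0.82 log units; beyond the scatter), so the outcome depends on the group carried by the chain, not merely on a chain being present. No available evidence explains this step.

As far as these compounds go, whether a longer chain, a terminal amine or a carboxylic acid on this chain would shift the number further remains open. Also open, from the compounds shown here alone, is whether the step from methoxymethyl to tert-butyl holds when the rest of the shared core is changed.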